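The compounds below may be only part of what the source reports. "The series", "measured", "known", "first", "only" and "open" are said of these compounds alone.

Measured compounds:
compound 1, `NC(=O)Cn1c(=O)n(C2OC(CO)[C@@H](O)[C@H]2O)c2nc(N)nc(O)c21`: 32%
compound 2, `COc1ccc(Cn2c(=O)n(C3OC(CO)[C@@H](O)[C@H]3O)c3nc(N)nc(O)c32)cc1`: 44%
compound 3, `Nc1nc(O)c2c(n1)n(C1OC(CO)[C@@H](O)[C@H]1O)c(=O)n2Cc1ccccc1`: 110%

In a functional assay on the whole organism (B cells) with Mus musculus as the target (on this read-out lower numbers stand for smaller maximal responses and higher numbers for larger maximal responses), compound 3 stands highest of the three; the step of a number 78 percentage points higher from compound 1 to compound 3 (beyond the scatter) and the step of a number 66 percentage points higher from compound 2 to compound 3 (beyond the scatter) both lie well beyond the scatter, and the step of a number 12 percentage points higher from compound 1 to compound 2 (beyond the scatter) is modest.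

Compound 4, `Nc1nc(O)c2c(n1)n(C1OC(CO)[C@@H](O)[C@H]1O)c(=O)n2CC(O)CO`, differs from compound 3 by 1,2-dihydroxyethyl in place of phenyl on a saturated chain carbon bound to an aromatic nitrogen. The step of a number 78 percentage points higher from compound 1 to compound 3 (beyond the scatter) bears most directly on this change, since there a phenyl entered on the same saturated chain carbon bound to an aromatic nitrogen and the maximal response rose strongly; the step of a number 66 percentage points higher from compound 2 to compound 3 (beyond the scatter) shows the same high standing of the bare phenyl. Removing the phenyl again is therefore expected to reverse most of that gain, with a large downward step a number 75 percentage points lower from compound 3 to compound 4 (beyond the scatter) expected. Compound 4 is estimated at 35%, within 15% to 65%.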

Compound 4, largest response reached (reported as maximal response), in percent of the reference or control that the assay uses: 136%
Compound 4: middle estimate off by 101 percentage points, on the low side; measured number outside the range, above it.
By their numbers in this assay, from the lowest: compound 1; then compound 2; then compound 3; then compound 4.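

In this assay the step of a number 26 percentage points higher from compound 3 to compound 4 (beyond the scatter) shows that an aromatic ring on the saturated chain carbon bound to an aromatic nitrogen is not required for a high maximal response. With a number 92 percentage points higher from compound 2 to compound 4 (beyond the scatter) and a number 104 percentage points higher from compound 1 to compound 4 (beyond the scatter) as well, 1,2-dihydroxyethyl gives the largest response among the four groups compared. No supporting evidence is available to explain these steps.

Whether the rise follows the two hydroxyl groups or the open chain itself remains unresolved. A plain propyl chain, a single-hydroxyl chain or an aminoalkyl chain at this place would help separate the two.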